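Acyl group variation on the shared core

The source may report more compounds than this note shows. Statements on the series, on what has been measured and on what is new or still open speak of the compounds shown alone.

Compound 3 `O=C(Nc1ccc(N2CCN(c3ccc(OC[C@@H]4CO[C@@](Cn5cncn5)(c5ccc(Cl)cc5Cl)O4)cc3)CC2)cc1)c1cccc(F)c1` gives 10800 nM in a functional assay on HepG2 cells (Homo sapiens) for inhibition, read by MTT assay, with a stated time of 48 h (a lower number here means a stronger inhibitor, a higher number a weaker inhibitor), the highest of the three numbers in hand. Compound 1 `CCC(=O)Nc1ccc(N2CCN(c3ccc(OC[C@@H]4CO[C@@](Cn5cncn5)(c5ccc(Cl)cc5Cl)O4)cc3)CC2)cc1` gives 5460 nM, and compound 2 `O=C(CCc1ccccc1)Nc1ccc(N2CCN(c3ccc(OC[C@@H]4CO[C@@](Cn5cncn5)(c5ccc(Cl)cc5Cl)O4)cc3)CC2)cc1` gives 5340 nM. The step of a 2.0-fold higher number from compound 1 to compound 3 (0.30 log units; within the scatter) and the step of a 2.0-fold higher number from compound 2 to compound 3 (0.31 log units; beyond the scatter) are both small. Compound 4 `O=C(Nc1ccc(N2CCN(c3ccc(OC[C@@H]4CO[C@@](Cn5cncn5)(c5ccc(Cl)cc5Cl)O4)cc3)CC2)cc1)c1ccco1` differs from compound 3 by furan-2-yl in place of 3-fluorophenyl on a carbonyl carbon. Within the data shown here, no measured step exchanges one aryl group for another on the carbonyl carbon, so none bears directly on this change; the three acyl variants so far, ethyl, phenethyl and 3-fluorophenyl, differ only by the sizes just given, so a step within the scatter, with no clear direction, is expected here. The value of compound 4 is estimated at 9000 nM, range 4000 nM to 20000 nM. This expectation corresponds to a 1.2-fold lower number from compound 3 to compound 4 (0.08 log units; within the scatter).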

Compound 4, half-maximal inhibitory concentration: 22300 nM
For compound 4 the middle estimate is 2.5-fold (0.39 log units) below the measured one; measured number above the stated range.
By their numbers in this assay, from the lowest: compounds 2, 1 and 3 (each within the scatter of the next, the first and the last beyond it); then compound 4.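

Furan-2-yl on the carbonyl carbon gives the weakest of the four compounds in this assay, with a 2.1-fold higher number from compound 3 to compound 4 (0.31 log units; beyond the scatter), a 4.1-fold higher number from compound 1 to compound 4 (0.61 log units; beyond the scatter) and a 4.2-fold higher number from compound 2 to compound 4 (0.62 log units; beyond the scatter). Among these compounds, this is the first aryl-for-aryl exchange, and it shows that the number at this position can shift with the aromatic ring alone, not only between aryl and chain groups. Nothing measured accounts for this step.

Still open, on these data alone, is whether other five-membered aromatic rings with a hetero atom read like furan-2-yl. Also open, as far as these compounds go, is how an acyl group carrying an amine or a carboxylic acid would read.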